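Fluoro added to the core phenyl of compound 2

The source may hold more compounds than are shown below. What is called first, only, known or untested is meant among the compounds shown, and "the series" means these compounds.

Compound 2 `O=C(NOCc1ccccc1Cl)c1cn(-c2ccccc2)nc1-c1ccccc1` gives 10300 nM in a functional assay on A549 cells (Homo sapiens) for antiproliferative activity, read by MTT assay, with a stated time of 48 h, in the presence of a further agent that is not named here; on this read-out higher numbers stand for weaker inhibition of growth and lower numbers for stronger inhibition of growth. Among the three measured compounds this is the high end of the numbers, though compound 1 `O=C(NOCc1ccccc1F)c1cn(-c2ccccc2)nc1-c1ccccc1` with 5940 nM and compound 3 `O=C(NOCc1ccc(Cl)cc1Cl)c1cn(-c2ccccc2)nc1-c1ccccc1` with 7350 nM lie within the scatter of it: a 1.7-fold higher number from compound 1 to compound 2 (0.24 log units; within the scatter), a 1.4-fold lower number from compound 2 to compound 3 (0.15 log units; within the scatter) and a 1.2-fold higher number from compound 1 to compound 3 (0.09 log units; within the scatter) are all small.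

Compound 4 `O=C(NOCc1ccccc1Cl)c1cn(-c2ccccc2)nc1-c1ccc(F)cc1` differs from compound 2 by fluoro in place of hydrogen on an aromatic carbon. Going by the values given here, no measured step touches this ring; the steps seen so far exchange substituents on the benzyloxy ring only, and every one of them, a 1.7-fold higher number from compound 1 to compound 2 (0.24 log units; within the scatter) and a 1.4-fold lower number from compound 2 to compound 3 (0.15 log units; within the scatter) among them, stayed within the scatter. A single added fluoro on the other aromatic ring therefore gives no ground to expect a step beyond the scatter in this assay; the estimated step is a 1.1-fold lower number from compound 2 to compound 4 (0.06 log units; within the scatter), in no firm direction. Compound 4 is accordingly expected to give about 9000 nM, with a range from 4000 nM to 20000 nM.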

Compound 4, concentration for 50% growth inhibition: 8330 nM
Compound 4: the middle estimate sits 1.1-fold (0.03 log units) above what was measured; low and high end bracket the measured number.
By their numbers in this assay, from the lowest: compounds 1, 3, 4 and 2 (each within the scatter of the next).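

Phenyl to 4-fluorophenyl, with the fluoro on an aromatic carbon para to a large group, is the first change shown on the core rather than on the benzyloxy ring, and in this assay it gives a 1.2-fold lower number from compound 2 to compound 4 (0.09 log units; within the scatter). Going by these compounds alone, a single fluoro at this position of the core of compound 2 therefore leaves the number within the scatter, as the substituent exchanges on the benzyloxy ring did, so the series so far shows no step beyond the scatter at either ring. No measurement here bears on the reason for a step of this size.

Going by these compounds, whether a larger group at this position, such as methoxy, an amine or a carboxylic acid, would move the number beyond the scatter remains open. Also open, on these data alone, is whether the same fluoro would behave alike on the other phenyl of the shared core.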